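Working notes: three measured analogues and a fourth

The compounds below may be only part of what the source reports. "The series", "measured", "known", "first", "only" and "open" are said of these compounds alone.

Measured so far:
compound 1, `NNC(=O)CSc1nnc(-c2ccncc2)o1`, 3260 nM
compound 2, `O=C(CSc1nnc(-c2ccncc2)o1)N/N=C/c1ccc(O)cc1`, 12200 nM
compound 3, `O=C(CSc1nnc(-c2ccncc2)o1)N/N=C/c1cccc(C(F)(F)F)c1`, 14900 nM

In a functional assay on SW 1116 cells (Homo sapiens) for cytotoxicity, read by MTT assay, with a stated time of 48 h (a higher number here means a weaker inhibitor, a lower number a stronger inhibitor), compound 1 gives 3260 nM, the lowest number of the three. Compound 2 gives 12200 nM, the second highest of the three numbers. Its nearest neighbour is compound 3 with 14900 nM, a gap within the scatter, so no order between compound 2 and compound 3 can be read from these two values. Its furthest neighbour is compound 1, and that gap lies beyond the scatter. Going by the values given here, no single-point step between measured compounds is available, so nothing on the size of the hydroxyphenyl-to-trifluoromethylphenyl change can be computed from these data.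

Compound 4, `O=C(CSc1nnc(-c2ccncc2)o1)N/N=C/c1ccccc1[N+](=O)[O-]`, has not yet been measured in this assay. It differs from compound 2 by 2-nitrophenyl in place of 4-hydroxyphenyl on a carbon with a double bond to nitrogen. The two aryl hydrazones already measured, compound 2 and compound 3, lie close together, and compound 4 carries a third aryl group in the same place. The number for compound 4 is therefore expected near that of compound 2, with the step of a 1.1-fold higher number from compound 2 to compound 4 (0.03 log units; within the scatter) expected to stay within the scatter. The estimate for compound 4 is 13000 nM, with a range from 5000 nM to 35000 nM.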

Compound 4, half-maximal inhibitory concentration: 30700 nM
Compound 4: middle estimate off by 2.4-fold (0.37 log units), on the low side; measured number inside the range.
By their numbers in this assay, from the lowest: compound 1; then compounds 2 and 3 (each within the scatter of the next); then compound 4.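

In this assay compound 2 at 12200 nM and compound 3 at 14900 nM lie within the scatter of each other, which alone left open whether the aryl group on a carbon with a double bond to nitrogen matters at all. The change to 2-nitrophenyl in place of 4-hydroxyphenyl gives a 2.5-fold higher number from compound 2 to compound 4 (0.40 log units; beyond the scatter) and so shows that the number can respond to the aryl group at this place, though only modestly, and that not every aryl exchange stays within the scatter, as the pair of compound 2 and compound 3 does. Nothing at hand gives a reason for this step.

A single exchange removes the hydroxyl and brings in the nitro group together, so the share of each in the step cannot be separated, nor can the effect of where the nitro group sits on the ring be told from that of the group itself. Also open, on these data alone, is how the number would respond to an unsubstituted phenyl, or to an aryl group carrying an amine or a carboxylic acid, at this same place.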